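The source may report more compounds than this note shows. Statements on the series, on what has been measured and on what is new or still open speak of the compounds shown alone.

Compound 1 `COc1ccc2[nH]cc(-c3nc(C(=O)Nc4cc(OC)c(OC)c(OC)c4)cs3)c2c1`: 84800 nM
Compound 2 `COc1cc(NC(=O)c2csc(-c3c[nH]c4ccc(Br)cc34)n2)cc(OC)c1OC`: > 100000 nM

In a functional assay on LNCaP cells (Homo sapiens) for cytotoxicity, read by MTT assay, with a stated time of 48 h, in the presence of a further agent that is not named here (on this read-out higher numbers stand for weaker inhibition and lower numbers for stronger inhibition), compound 1 gives 84800 nM. For compound 2 the value > 100000 nM is a limit of the assay rather than a number, as recorded by the limit of > 100000 nM in this assay, at which 1 of the 2 values shown sits. The step of an at least 1.1-fold higher number from compound 1 to compound 2 (0.07 log units; that floor lies within the scatter) is thus only a floor and lies within the scatter. Compound 3 `COc1cc(NC(=O)c2csc(-c3c[nH]c4ccc(F)cc34)n2)cc(OC)c1OC` differs from compound 2 by fluoro in place of bromo on an aromatic carbon. Among the compounds with values here, the single step that bears on this exchange gives no direction, so for compound 3 no change beyond the scatter is expected a step that the limit leaves unreadable from compound 2 to compound 3. Compound 3 is therefore estimated at 110000 nM, between 50000 nM and 300000 nM, most likely reported again as a limit.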

Compound 3, half-maximal inhibitory concentration: 88500 nM
The estimate for compound 3 lay 1.2-fold (0.09 log units) above the measured number; the range from low to high includes it.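

In this assay compound 3 gives a real number at this position, so fluoro and methoxy on this aromatic carbon can be compared directly, and they do not separate: a 1.0-fold higher number from compound 1 to compound 3 (0.02 log units; within the scatter). The exchange of bromo for fluoro gives only a floor that cannot show the size of any change: an at least 1.1-fold lower number from compound 2 to compound 3 (0.05 log units; that floor lies within the scatter). Compound 2 remains at a limit of the assay: the limit of > 100000 nM in this assay, at which 1 of the 3 values shown sits.

On these data alone, the true value of compound 2 stays open. So does whether an amine or a carboxylic acid on this carbon would move the number beyond the scatter from those of compound 1 and compound 3.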